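A few compounds are considered here, and "the series" means these few. Any claim that something is new, unique, unknown or untested is made for them only; others in the source may bear on it.

Measured compounds:
compound 1 `CC(C)(C)CCn1nc(C2CC2)c(O)c(C2=NS(=O)(=O)c3cc(NS(C)(=O)=O)ccc3N2)c1=O`: > 1000 nM
compound 2 `CC(C)CCn1nc(-c2cccs2)c(O)c(C2=NS(=O)(=O)c3cc(N(C)S(C)(=O)=O)ccc3N2)c1=O`: > 33000 nM

Compound 1, structure `CC(C)(C)CCn1nc(C2CC2)c(O)c(C2=NS(=O)(=O)c3cc(NS(C)(=O)=O)ccc3N2)c1=O`, is one of two compounds with a read-out in an ADME assay on Huh-7 cells (Homo sapiens) for cytotoxicity, with a stated time of 72 h; on this read-out higher numbers stand for lower toxicity in this test and lower numbers for higher toxicity in this test. In this assay compound 1 gives > 1000 nM, which is a limit rather than a number. Compound 2, structure `CC(C)CCn1nc(-c2cccs2)c(O)c(C2=NS(=O)(=O)c3cc(N(C)S(C)(=O)=O)ccc3N2)c1=O`, gives > 33000 nM, again a limit rather than a number. Going by the values given here, both values are therefore open-ended, and no step between measured compounds is available.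

Compound 3, structure `CC(C)(C)CCn1nc(CC(C)(C)C)c(O)c(C2=NS(=O)(=O)c3cc(NS(C)(=O)=O)ccc3N2)c1=O`, has not been measured. It differs from compound 1 in one place: neopentyl in place of cyclopropyl on an aromatic carbon.

With only limits to go on, no step beyond the usual scatter is expected from compound 1 to compound 3 in this assay; the expected step is a step that the limit leaves unreadable from compound 1 to compound 3. The value of compound 3 in this assay is estimated at 3000 nM, within 1000 nM to 30000 nM, and most likely again reported as a limit.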

Compound 3, half-maximal cytotoxic concentration in the Huh-7 assay: > 1000 nM
Compound 3 gave a limit, no number; the forecaster's own chance of this, stated with the estimate: 75%; the middle value is on the limit's open side.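

Going by these compounds alone, every value of compound 1 and compound 3 is a limit, so no step between them can be read. In a physicochemical assay for solubility, at pH 7.4 (on this read-out lower numbers stand for lower solubility and higher numbers for higher solubility), compound 1 gives > 50000 nM, a limit. In the physicochemical assay compound 3 gives > 100000 nM, also a limit. The compounds shown leave open whether neopentyl in place of cyclopropyl shifts either read-out at all.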